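Trimming one ethyl of compound 2

The source may hold more compounds than are shown below. What is called first, only, known or untested is meant among the compounds shown, and "the series" means these compounds.

In a functional assay on the whole organism (Abdomen) with Mus musculus as the target (on this read-out lower numbers stand for an effect already at smaller amounts and higher numbers for an effect only at larger amounts of compound), compound 2 (`CCc1nc(Cc2c[nH]cn2)c(CC)s1`) gives 1.8 mg/kg and compound 3 (`CCc1sc(C)nc1Cc1c[nH]cn1`) gives 2.3 mg/kg, so the two stand level within the scatter. Compound 1 (`Cc1nc(Cc2c[nH]cn2)c(C)s1`) gives > 30 mg/kg, which is a limit.

Compound 4 (`CCc1nc(Cc2c[nH]cn2)c(C)s1`) differs from compound 2 by hydrogen in place of methyl on a saturated chain carbon bound to an aromatic carbon. Among the measured compounds shown here, two measured steps bear on this. On the other ethyl, the same change gave a 1.3-fold higher number from compound 2 to compound 3 (0.11 log units; within the scatter). On this ethyl, its reverse gave an at least 13-fold lower number from compound 1 to compound 3 (1.11 log units; beyond the scatter), with a methyl rather than an ethyl as the other group. A large step towards a higher number in this assay is therefore expected, perhaps softened by the ethyl retained in compound 4. The expected step is an 8.3-fold higher number from compound 2 to compound 4 (0.92 log units; beyond the scatter). Compound 4 is estimated at 15 mg/kg, with an expected range of 4 mg/kg to 60 mg/kg.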

Compound 4, dose for half-maximal effect: > 30 mg/kg
Compound 4: a limit, no number; the forecaster's own chance of this, stated with the estimate: 40%; middle value at least 2.0-fold (0.30 log units) from the limit.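

In this assay, trimming this ethyl to methyl gives an at least 16-fold higher number from compound 2 to compound 4 (1.22 log units; beyond the scatter), whereas the same trim on the other ethyl gives a 1.3-fold higher number from compound 2 to compound 3 (0.11 log units; within the scatter), so the two ethyl groups do not count equally. The requirement for this ethyl now holds with either ethyl or methyl as the other group: the same change on two cores in this assay, an at least 13-fold lower number (1.11 log units; beyond the scatter) from compound 1 to compound 3 and an at least 16-fold lower number (1.22 log units; beyond the scatter) from compound 4 to compound 2; the limit leaves it open whether they differ

The step between compound 1 and compound 4 cannot be read, as both values are limits. Still open, as far as these compounds go, is whether a longer chain such as propyl, or an amine, in place of this ethyl would keep the number of compound 2.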